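Cytotoxicity of an acylsulfonamide variant of compound 1

This account rests on a few compounds, and the source may have more. Where it says the series, first, only, none or still open, it means among the compounds named here.

Among the compounds with values here, compound 1 `Cc1cc(C)cc(S(=O)(=O)c2c(C(=O)N[C@@H]3CCN(Cc4cccnc4)C3)[nH]c3ccc(Cl)cc23)c1` is the only member of this set with a definite number in an ADME assay on MT4 cells (Homo sapiens) for cytotoxicity, read by MTT assay, with a stated time of 5 days (a higher number here means that more compound is tolerated, a lower number that less compound is tolerated), where compound 1 gives 36500 nM. Compound 2 `Cc1cc(C)cc(S(=O)(=O)c2c(C(=O)N[C@@H]3CCN(Cc4ccccc4C#N)C3)[nH]c3ccc(Cl)cc23)c1` reaches only a limit of the assay in this assay, at which compound 2 gives >= 186000 nM. Between the two stands the step of an at least 5.0-fold higher number from compound 1 to compound 2 (0.70 log units; beyond the scatter), and the limit of >= 186000 nM in this assay, at which 1 of the 2 values shown sits, is the one point of evidence on it.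

Compound 3 `CCS(=O)(=O)NC(=O)c1[nH]c2ccc(Cl)cc2c1S(=O)(=O)c1cc(C)cc(C)c1` differs from compound 1 by ethylsulfonyl in place of 1-((pyridin-3-yl)methyl)pyrrolidin-3-yl on an amide-type nitrogen. Within the data shown here, the one measured step, from compound 1 to compound 2, changed a group on a saturated chain carbon bound to an amine nitrogen in a ring, not the amide-type nitrogen, so it bears on this change only loosely. It does show that departing from compound 1 at the periphery of the shared core raised the number by at least the modest amount given. A step in the same direction, beyond the scatter, is therefore expected, with a fair chance that compound 3 also reaches a limit rather than a number. The estimated step is a 2.7-fold higher number from compound 1 to compound 3 (0.44 log units; beyond the scatter). For compound 3 the expected value is 100000 nM, within a range from 30000 nM to 200000 nM.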

Compound 3, half-maximal cytotoxic concentration: > 283000 nM
Compound 3 was reported as a limit; the forecaster's own chance of this, stated with the estimate: 45%; at least 2.8-fold (0.45 log units) between middle value and limit.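

Within the data shown here, replacing the whole 1-((pyridin-3-yl)methyl)pyrrolidin-3-yl group on the amide-type nitrogen with ethylsulfonyl gives in this assay a step of an at least 7.7-fold higher number from compound 1 to compound 3 (0.88 log units; beyond the scatter), and this step is the first evidence on a change at this nitrogen. Compound 3 gives a limit of the assay and not a number: the limit of > 283000 nM in this assay, at which 1 of the 3 values shown sits.

Unlike the earlier step, this change removes the pyrrolidine ring as well as the pyridin-3-yl, so the higher number does not require the rest of that substituent to stay in place; compound 2 and compound 3, the two shown without the pyridin-3-yl, both stop at a limit, and compound 1, which carries it, is the only one with a definite number.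

Because this single change removes both rings and brings in the sulfonyl group at once, the compounds shown leave open which of these parts accounts for the step. Going by these compounds, how a plain ethyl or a longer alkyl chain on the amide-type nitrogen, or a free amine on the pyrrolidine ring, would read in this assay also remains open.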